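This account rests on a few compounds, and the source may have more. Where it says the series, first, only, none or still open, it means among the compounds named here.

In an ADME assay on HeLa cells (Homo sapiens) for cytotoxicity, read by MTT assay, with a stated time of 2 days (on this read-out lower numbers stand for higher toxicity in this test and higher numbers for lower toxicity in this test), compound 1 (`CCOC(=O)c1sc2cc(Oc3ccnc(C(=O)NC)c3)ccc2c1CC`) gives 16700 nM while compound 2 (`CNC(=O)c1cc(Oc2ccc3cc(C(=O)OC(C)C)sc3c2)ccn1`) gives 45000 nM and compound 3 (`CNC(=O)c1cc(Oc2ccc3c(C)c(C(=O)OC(C)C)sc3c2)ccn1`) gives 9600 nM on the same scale. The gap between compound 3 and compound 1 lies within the usual scatter, whereas the gap between compound 3 and compound 2 lies beyond it.

Compound 4 (`CNC(=O)c1cc(Oc2ccc3c(C)c(C(=O)OCc4ccccc4)sc3c2)ccn1`) has not yet been measured. It differs from compound 3 in one place (benzyl in place of isopropyl on an oxygen next to a carbonyl group) with benzyl in place of isopropyl on an oxygen next to a carbonyl group.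

Among the compounds with values here, the only measured single-place step is a 4.7-fold lower number from compound 2 to compound 3 (0.67 log units; beyond the scatter) with methyl in place of hydrogen on an aromatic carbon. That step lies elsewhere in the structure, so it serves only as a rough guide to how far one small change can move this read-out. Compound 1 and compound 3 carry different groups on that oxygen, but they also differ elsewhere, so they do not isolate the change. The direction therefore rests on thin evidence, and only a slight lean towards a lower number is expected in this assay for the larger group. The estimated step is a 1.3-fold lower number from compound 3 to compound 4 (0.11 log units; within the scatter) and stays within the scatter. For compound 4 the estimated value is 7500 nM with an expected range from 2800 nM to 20000 nM in this test.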

Compound 4, half-maximal cytotoxic concentration: 18100 nM
The estimate for compound 4 lay 2.4-fold (0.38 log units) below the measured number, and the stated range covers the measured number.
By their numbers in this assay, from the lowest: compounds 3, 1 and 4 (each within the scatter of the next); then compound 2.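

Within the data shown here, the first direct reading at this position comes from this assay: with benzyl in place of isopropyl on an oxygen next to a carbonyl group, the result is a 1.9-fold higher number from compound 3 to compound 4 (0.28 log units; within the scatter). Among these compounds, the two compounds therefore cannot be told apart here, so a group with a six-membered aromatic ring can stand on this oxygen without a shift that exceeds the usual scatter, whereas the one earlier single-place step, made elsewhere in the structure, is a 4.7-fold lower number from compound 2 to compound 3 (0.67 log units; beyond the scatter) and lies beyond it. Nothing measured here offers an explanation for this result, and no cause can be assigned to the swap.

The compounds shown leave open whether the tolerance seen for isopropyl and benzyl extends to very different ends at this place, such as a carboxylic acid in place of the whole isopropoxycarbonyl group, or a longer chain ending in an amine on the same oxygen. They also leave open whether a benzyl ring carrying a fluorine or a methoxy group would stay within the scatter of these two compounds, and whether benzyl would read the same on a core lacking the methyl group of compound 4.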